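Replacing the 4-methylphenyl of compound 2

The compounds below may be only part of what the source reports. "The series", "measured", "known", "first", "only" and "open" are said of these compounds alone.

Compounds measured in an ADME assay on MDCKII-LE cells (Canis lupus familiaris) for permeability; on this read-out lower numbers stand for lower permeability and higher numbers for higher permeability:
compound 1 `Cc1cnc(NC(=O)c2cc(Oc3ccc(C(=O)N(C)C)nc3)c3cc(C)oc3c2)cn1` gives 28.5 10^-6 cm/s
compound 2 `Cc1ccc(Oc2cc(C(=O)Nc3cnc(C)cn3)cc3oc(C)cc23)cc1` gives 0.3 10^-6 cm/s

Of these two numbers, compound 2 has the lower one, and compound 1 stands higher by a gap well beyond the scatter. Compound 3 `CNC(=O)c1cnc(Oc2cc(C(=O)Nc3cnc(C)cn3)cc3oc(C)cc23)cn1` has not yet been measured. It carries 5-(methylcarbamoyl)pyrazin-2-yl in place of 4-methylphenyl on an oxygen on an aromatic ring. Among the measured compounds shown here, no measured pair isolates this kind of change, so the expectation leans only on compound 1 (28.5 10^-6 cm/s), whose group on that oxygen also holds a carbonyl. A rise beyond the scatter is expected in this assay, estimated as (a 33-fold higher number from compound 2 to compound 3 (1.52 log units; beyond the scatter)). Compound 3 is estimated at 10 10^-6 cm/s (expected range 3 10^-6 cm/s to 28 10^-6 cm/s).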

Compound 3, apparent permeability: 20.9 10^-6 cm/s
Compound 3: the middle estimate sits 2.1-fold (0.32 log units) below what was measured; measured number inside the range.
By their numbers in this assay, from the lowest: compound 2; then compounds 3 and 1 (each within the scatter of the next).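

In this assay, among the compounds shown here, the group on the oxygen on an aromatic ring turns out to matter greatly: 5-(methylcarbamoyl)pyrazin-2-yl in place of 4-methylphenyl gives a 70-fold higher number from compound 2 to compound 3 (1.84 log units; beyond the scatter) in a single change, the first step at this position. The entering group brings 1 hydrogen-bond donor and 3 hydrogen-bond acceptors where 4-methylphenyl has none, and it places compound 3 within the scatter of compound 1, whose group on that oxygen also holds a carbonyl. Nothing measured here identifies which part of the exchange accounts for the step.

The compounds shown do not separate the pyrazine ring from the methylcarbamoyl, which a plain pyrazin-2-yl or a 4-(methylcarbamoyl)phenyl on the same oxygen would do. On these data alone, how a carboxylic acid or an amine would behave at this position also remains open.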